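Swapping Chloro for Methylsulfanyl on a Pair at the Limit

A few compounds are considered here, and "the series" means these few. Any claim that something is new, unique, unknown or untested is made for them only; others in the source may bear on it.

Measured so far:
compound 1, `COc1cc(-n2ncnc2-c2ccc(Cl)cc2)cc(OC)c1OC`, gives only the limit > 10000 nM in a functional assay on HeLa cells (Homo sapiens) for antiproliferative activity, read by MTT assay, with a stated time of 72 h; a higher number here means a weaker inhibitor, a lower number a stronger inhibitor.
compound 2, `COc1cc(-c2ncnn2-c2ccccc2)cc(OC)c1OC`, gives only the limit > 10000 nM in this assay.

Compound 1 therefore stands at the limit rather than at a number; (the limit of > 10000 nM in this assay, at which 2 of the 2 values shown sit). Going by the values given here, compound 2 differs from it in more than one place, so no single step can be drawn between the two. Compound 3, `COc1cc(-n2ncnc2-c2ccc(SC)cc2)cc(OC)c1OC`, differs from compound 1 by methylsulfanyl in place of chloro on an aromatic carbon. Among the compounds with values here, with the only known value a limit, the expected step, a number no higher from compound 1 to compound 3 (the limit leaves the size open), is none beyond the scatter. Compound 3 is estimated at 10000 nM, between 2000 nM and 50000 nM.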

Compound 3, half-maximal inhibitory concentration: 150 nM
The estimate for compound 3 lay 67-fold (1.82 log units) above the measured number; the whole stated range lies above it.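

Methylsulfanyl in place of chloro on an aromatic carbon, para to a large group, gives an at least 66-fold lower number from compound 1 to compound 3 (1.82 log units; beyond the scatter) in this assay. A single change at this position is therefore enough to bring the core of compound 1 off the limit and to a measurable number. The size of the step remains a minimum, as compound 1 has only a limit: the limit of > 10000 nM in this assay, at which 2 of the 3 values shown sit.

As far as these compounds go, whether an amine, a methoxy group or a longer thioether chain would serve at this position stays open. So does whether the sulfur or its methyl accounts for the step.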